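The compounds below may be only part of what the source reports. "The series", "measured", "known", "first", "only" and "open" are said of these compounds alone.

Values in a functional assay, tested at 100 ug/mL; a lower number here means a weaker effect, a higher number a stronger effect of the compound at the concentration tested:
- compound 1 `COc1ccc(C2=NN(c3ccccc3)C(c3ccc(C)cc3)C2S(=O)(=O)CC2=NCCO2)cc1`: 67.7%
- compound 2 `O=S(=O)(CC1=NCCO1)C1C(c2ccccc2)=NOC1c1ccccc1`: 56.6%
- compound 3 `O=S(=O)(CC1=NCCO1)C1C(c2ccccc2)=NN(c2ccccc2)C1c1ccccc1`: 48.1%

Compound 2 holds the second highest of the three numbers. Compound 3 is nearest to it, and the gap between compound 2 and compound 3 lies within the scatter of this assay, so the two cannot be ordered. Compound 1 lies further away and its gap to compound 2 is beyond the scatter; compound 1 therefore stands higher than compound 2 on the numbers shown.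

The next compound, compound 4 `O=S(=O)(CC1=NCCS1)C1C(c2ccccc2)=NOC1c1ccccc1`, differs from compound 2 in one place: a group of 5 heavy atoms (3 carbon, 1 nitrogen, 1 sulfur; one five-membered non-aromatic ring with 2 hetero atoms) in place of a group of 5 heavy atoms (3 carbon, 1 nitrogen, 1 oxygen; one five-membered non-aromatic ring with 2 hetero atoms), on a saturated chain carbon bound to a sulfonyl sulfur. Going by the values given here, no pair among the measured compounds shows this change, so there is no measured step to go by. The change exchanges one ring of five heavy atoms for another of the same size with one hetero atom swapped, and with no step shown for it, no movement beyond the scatter is expected in this assay. Compound 4 is expected to give about 55%, in the range 40% to 70%. This estimate corresponds to a step of a number 1.6 percentage points lower from compound 2 to compound 4 (within the scatter), expected to stay within the scatter.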

Compound 4, a percentage reported as activity, at one concentration (the size of the read-out at that concentration, not a potency): "not active" (no number reported)
The entry for compound 4 holds no number; there is nothing to compare the estimate with.
By their numbers in this assay, from the lowest: compounds 3 and 2 (each within the scatter of the next); then compound 1.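

In this assay, going by these compounds alone, compound 4 is recorded as not active without a number, so no step from compound 2 to compound 4 can be read. The compounds shown leave open what size of effect the sulfur-bearing five-membered ring has in place of the oxygen-bearing one. No measurement shown bears on an explanation.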